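The compounds below may be only part of what the source reports. "The series", "measured", "known", "first", "only" and "open" are said of these compounds alone.

Measured compounds:
- compound 1, `O=C(Cc1cccnc1)c1cc2cc(F)ccc2[nH]1`: 36000 nM
- compound 2, `O=C(Cc1cccnc1)c1cc2c(F)cccc2[nH]1`: 153000 nM
- compound 3, `O=C(Cc1cccnc1)c1cc2cc(Cl)ccc2[nH]1`: 24600 nM

All three share one core and differ only in the halogen and where it sits. In an assay on isolated protein for inhibition of Indoleamine 2,3-dioxygenase 1 (Homo sapiens), read by spectrophotometry (on this read-out higher numbers stand for weaker inhibition and lower numbers for stronger inhibition), compound 3 gives the lowest of the three numbers; compound 1 sits closest to it, and compound 2 lies furthest, its number beyond the scatter from that of compound 3. Among the measured compounds shown here, the only single-point step available is a 1.5-fold lower number from compound 1 to compound 3 (0.17 log units; within the scatter), a halogen exchange at the same aromatic carbon that moves the number little.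

Compound 4, `O=C(Cc1cccnc1)c1cc2cc(O)ccc2[nH]1`, has not been measured. It differs from compound 3 as follows: hydroxy in place of chloro on an aromatic carbon. For the measured compounds named here, no measured step introduces a hydroxy group, so the halogen exchange from compound 1 to compound 3 bears only loosely on this change; it shows that the number tolerates a swap at this carbon without moving beyond the scatter. On these data alone, the estimate for compound 4 therefore stays near compound 3, with a wide range because a hydroxy is untested here: a 2.0-fold higher number from compound 3 to compound 4 (0.31 log units; beyond the scatter) is expected, giving an estimated 50000 nM, between 15000 nM and 200000 nM.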

Compound 4, half-maximal inhibitory concentration: 37000 nM
Compound 4: middle estimate off by 1.4-fold (0.13 log units), on the high side; measured number inside the range.
By their numbers in this assay, from the lowest: compounds 3, 1 and 4 (each within the scatter of the next); then compound 2.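

Hydroxy at this carbon gives a 1.5-fold higher number from compound 3 to compound 4 (0.18 log units; within the scatter) and a 1.0-fold higher number from compound 1 to compound 4 (0.01 log units; within the scatter) in this assay, so chloro, fluoro and hydroxy cannot be told apart here. The earlier step covered only an exchange of one halogen for another, whereas this result extends the tolerance at this carbon to a group with one hydrogen-bond donor and one hydrogen-bond acceptor, neither of which the halogens carry. No supporting measurement bears on this result.

Still open, on these data alone, is whether a methoxy, an amine or a carboxylic acid at this carbon would also stay within the scatter of these three compounds. Also open, as far as these compounds go, is whether hydroxy in place of the fluoro of compound 2 would leave its number where it stands.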